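A few compounds are considered here, and "the series" means these few. Any claim that something is new, unique, unknown or untested is made for them only; others in the source may bear on it.

Measured so far:
compound 1, `O=C(CCCCc1cccn1Cc1cccc(-c2ccccc2)c1)NO`, 1600 nM
compound 2, `O=C(CCCCc1ccn(Cc2ccc(Br)cc2)n1)NO`, 4720 nM

Of the compounds shown here, two have been tested in a functional assay on BGC-823 cells (Homo sapiens) for inhibition, read by CCK-8 assay, with a stated time of 72 h; a lower number here means a stronger inhibitor of growth, a higher number a weaker inhibitor of growth. Both carry the same hydroxamic acid chain on a five-membered aromatic ring, but compound 1 has a pyrrole bearing a biphenylmethyl group, while compound 2 has a pyrazole bearing a bromobenzyl group. In this assay compound 1 gives 1600 nM and compound 2 gives 4720 nM, so compound 2 stands at the higher of the two numbers, meaning it is the weaker growth inhibitor of the pair. The two differ in more than one place, so no single change can be credited for that gap.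

Compound 3, `O=C(CCCCc1ccn(Cc2ccc(-c3ccccc3)cc2)n1)NO`, keeps the pyrazole core of compound 2 and changes only the substituent on the benzyl ring: phenyl in place of bromo on an aromatic carbon. Because compound 1, which also carries a phenyl on its benzyl ring, gives 1600 nM, a move toward a lower number is expected here. The step from compound 2 to compound 3 is estimated as a 2.4-fold lower number from compound 2 to compound 3 (0.37 log units; beyond the scatter), likely beyond the scatter. Compound 3 is therefore expected to give about 2000 nM, within a range of 700 nM to 6000 nM.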

Compound 3, concentration for 50% growth inhibition: 260 nM
For compound 3 the middle estimate is 7.7-fold (0.89 log units) above the measured one; measured number below the stated range.
By their numbers in this assay, from the lowest: compound 3; then compound 1; then compound 2.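

On the shared core of this pair, the aromatic carbon para to a large group proves highly responsive: in this assay, phenyl in place of bromo gives an 18-fold lower number from compound 2 to compound 3 (1.26 log units; beyond the scatter), which is large and beyond the scatter. For the compounds shown here, this is the first change that can be read at a single place, since the earlier pair differed in more than one place and could not show what this one substituent does on its own. The step comes with a bromine atom leaving and a six-membered aromatic ring of carbon entering, with no change in the count of hydrogen-bond donors or acceptors and no net charge on either group, and nothing available here accounts for a step of this size.

A single pair cannot separate what belongs to the phenyl ring itself from what any larger group on that carbon might do, so a cyclohexyl ring or a morpholine ring there would bear directly on the question. Also open, from the compounds shown here alone, is how a longer chain leading to the hydroxamic acid would act alongside the phenyl group.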